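A Single Change on the Chlorinated Ring of Compound 1

The compounds below may be only part of what the source reports. "The series", "measured", "known", "first", "only" and "open" are said of these compounds alone.

Of the compounds shown here, three sharing one core have been tested in a functional assay on HEK293 cells for activation of melanin-concentrating hormone receptor 1 (Homo sapiens), read by inositol phosphate accumulation; on this read-out higher numbers stand for an effect only at larger amounts of compound and lower numbers for an effect already at smaller amounts. Compound 1 `CCCc1cc(N)c2cc(NC(=O)/C=C/c3ccc(Cl)c(Cl)c3)ccc2n1` gives 990 nM, the highest number of the three. Compound 3 `CCCCc1ccc(/C=C/C(=O)Nc2ccc3nc(CCC)cc(N)c3c2)cc1` gives 740 nM, which lies within the usual scatter of compound 1, so the two cannot be told apart. Compound 2 `CCCc1cc(N)c2cc(NC(=O)C3CCC(c4ccc(Cl)cc4)CC3)ccc2n1` gives 370 nM, a gap beyond the scatter, so compound 2 acts at smaller amounts than compound 1. The unmeasured compound 4 `CCCc1cc(N)c2cc(NC(=O)/C=C/c3ccccc3Cl)ccc2n1` differs from compound 1 in a single place: 2-chlorophenyl in place of 3,4-dichlorophenyl on a double-bonded chain carbon bound to a double-bonded chain carbon. Within the data shown here, no measured pair shows this kind of change, so its size is uncertain; a modest rise in the number, perhaps just beyond the scatter, seems most likely. Compound 4 is expected to give about 2000 nM, with a range from 600 nM to 6000 nM, meaning an estimated step of a 2.0-fold higher number from compound 1 to compound 4 (0.31 log units; beyond the scatter).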

Compound 4, half-maximal effective concentration: 500 nM
Estimate against measurement, compound 4: 4.0-fold (0.60 log units) above; measured number below the stated range.
By their numbers in this assay, from the lowest: compounds 2, 4, 3 and 1 (each within the scatter of the next, the first and the last beyond it).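

In this assay, 2-chlorophenyl in place of 3,4-dichlorophenyl on a double-bonded chain carbon gives a 2.0-fold lower number from compound 1 to compound 4 (0.30 log units; within the scatter), so the two cannot be told apart. This first pair differing in one place shows that this aromatic group can go from two chlorines to one without a step beyond the scatter. No measurement at hand offers a reason for this result.

From the compounds shown here alone, the number of chlorines and their places changed together here, and their separate contributions remain unknown. Also open, going by these compounds, is how a plain phenyl, a methoxy group or an amine on this ring would read.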